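The source may report more compounds than this note shows. Statements on the series, on what has been measured and on what is new or still open speak of the compounds shown alone.

Measured in a functional assay on A549 cells (Homo sapiens) for antiproliferative activity, read by MTT assay, with a stated time of 48 h; a higher number here means a weaker inhibitor, a lower number a stronger inhibitor:
- compound 1 `Clc1ccc2[nH]c(-c3cn(-c4ccccc4)nc3-c3ccccc3)nc2c1`: 2370 nM
- compound 2 `Fc1ccc(-c2nn(-c3ccccc3)cc2-c2nc3cc(Cl)ccc3[nH]2)cc1`: 1320 nM

Compound 2 stands level with compound 1, since a 1.8-fold lower number from compound 1 to compound 2 (0.25 log units; within the scatter) does not separate them. Compound 3 `Cc1ccc2[nH]c(-c3cn(-c4ccccc4)nc3-c3ccc(F)cc3)nc2c1` follows from compound 2 by methyl in place of chloro on an aromatic carbon. That one measured step is a different change, fluoro in place of hydrogen, so no measurement tests this swap directly. In this assay no shift beyond the scatter is therefore expected. The expected change is a 1.4-fold higher number from compound 2 to compound 3 (0.13 log units; within the scatter). For compound 3 the estimated value is 1800 nM, with an expected range of 700 nM to 4500 nM.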

Compound 3, half-maximal inhibitory concentration: 1440 nM
Compound 3: the middle estimate sits 1.3-fold (0.10 log units) above what was measured; measured number inside the range.
By their numbers in this assay, from the lowest: compounds 2, 3 and 1 (each within the scatter of the next).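

In this assay, among these compounds, the first change at this aromatic carbon of the fused system, methyl in place of chloro, gives a 1.1-fold higher number from compound 2 to compound 3 (0.04 log units; within the scatter) and so does not separate the two compounds. At this position, with the fluoro group kept in place, the assay therefore tells these two small groups apart no better than its usual scatter allows. No available measurement offers an explanation for this result. From the compounds shown here alone, whether an amine or a carboxylic acid at this carbon would also leave the number within the scatter remains open.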